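Swapping phenyl for heptyl in a cell toxicity test

A few compounds are considered here, and "the series" means these few. Any claim that something is new, unique, unknown or untested is made for them only; others in the source may bear on it.

Tested in an ADME assay on HaCaT cells (Homo sapiens) for cytotoxicity, read by MTT assay, with a stated time of 72 h (on this read-out higher numbers stand for weaker inhibition and lower numbers for stronger inhibition), compound 1 `CC(C)(C)C1=CC(=O)C(NCc2ccccc2)=CC1=O` gives 28000 nM while compound 2 `CCCCNC1=CC(=O)C=C(C[C@]2(C)[C@@H](C)CC[C@]3(C)C(C)=CCC[C@@H]23)C1=O` gives 16000 nM and these two numbers lie within the usual scatter of each other. Compound 3 `CCCCCCCCNC1=CC(=O)C(C(C)(C)C)=CC1=O` differs from compound 1 by a single swap heptyl in place of phenyl on a saturated chain carbon bound to an amine nitrogen that puts heptyl in place of phenyl on a saturated chain carbon bound to an amine nitrogen. Within the data shown here, no measured pair shows what such a swap does, so no change beyond the scatter is expected in this assay here. The expected move is a 1.4-fold lower number from compound 1 to compound 3 (0.15 log units; within the scatter) and it stays small. For compound 3 the estimated value is 20000 nM with an expected range from 7000 nM to 55000 nM across repeat measurements.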

Compound 3, half-maximal inhibitory concentration: > 100000 nM
Compound 3 ended at the assay's limit (the forecaster's own chance of this, stated with the estimate: 10%); middle value at least 5.0-fold (0.69 log units) away from the limit.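

At this position the change clearly matters: heptyl in place of phenyl on a saturated chain carbon bound to an amine nitrogen gives an at least 3.5-fold higher number from compound 1 to compound 3 (0.55 log units; beyond the scatter) in this assay, which means weaker inhibition. Compound 3 gives > 100000 nM, which is a limit of the assay and not a number. The full size of the step stays unknown because the reading stops there: the limit of > 100000 nM in this assay, at which 1 of the 3 values shown sits.

On these data alone, whether the shift comes from losing the aromatic ring or from the chain itself remains open. A cyclohexyl group in the same place would help separate the two.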